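A few compounds are considered here, and "the series" means these few. Any claim that something is new, unique, unknown or untested is made for them only; others in the source may bear on it.

Three compounds have been measured in a functional assay on SW-620 cells (Homo sapiens) for inhibition, read by MTT assay, with a stated time of 72 h; a lower number here means a stronger inhibitor, a higher number a weaker inhibitor:

Compound 1 `O=C1O/C(=C\Cn2ncc(=O)[nH]c2=O)C(OCc2ccccc2)=C1OCc1ccccc1` gives 36500 nM.
Compound 2 `NC1(CCn2ncc(=O)[nH]c2=O)OC(=O)C(OCc2ccccc2)=C1OCc1ccccc1` gives > 100000 nM, which is a limit of the assay rather than a number.
Compound 3 `O=C1O/C(=C\Cn2c(=O)[nH]c(=O)[nH]c2=O)C(OCc2ccccc2)=C1OCc1ccccc1` gives > 100000 nM, also a limit of the assay.

Compound 2 therefore stands at the limit of > 100000 nM in this assay, at which 2 of the 3 values shown sit, so only a range is known for it, and any number it would give lies past that limit. The unmeasured compound 4 `Cc1cn(CCC2(N)OC(=O)C(OCc3ccccc3)=C2OCc2ccccc2)c(=O)[nH]c1=O` differs from compound 2 in one place: a group of 9 heavy atoms (5 carbon, 2 nitrogen, 2 oxygen; one six-membered aromatic ring with 2 hetero atoms) in place of a group of 8 heavy atoms (3 carbon, 3 nitrogen, 2 oxygen; one six-membered aromatic ring with 3 hetero atoms), on a saturated chain carbon, two bonds along the chain from a saturated ring carbon. Going by the values given here, the only measured step that bears on such an exchange of one heterocyclic ring for another is an at least 2.7-fold higher number from compound 1 to compound 3 (0.43 log units; beyond the scatter), where the exchange took place on the related core of compound 1 and weakened inhibition. That step involves a different pair of rings and a different chain, so it is only a loose guide, and it starts from a number while compound 2 starts from a limit. Among the compounds with values here, with compound 2 already at the limit, no upward step can be measured, and a downward step would have to be large to produce a number at all. Compound 4 is therefore expected to remain a weak inhibitor, with the step that the limit leaves unreadable from compound 2 to compound 4 carrying little meaning beyond the limit. The estimate for compound 4 in this assay is 120000 nM, with a range from 30000 nM to 400000 nM.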

Compound 4, half-maximal inhibitory concentration: > 100000 nM
Compound 4 gave a limit, no number; the forecaster's own chance of this, stated with the estimate: 65%; the middle value does not contradict the limit.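

In this assay compound 4 gives > 100000 nM, which is a limit of the assay and not a number. Going by these compounds alone, compound 2 also sits at a limit, so no step from compound 2 to compound 4 can be read. The compounds shown leave open whether exchanging one ring group for the other changes inhibition on this core at all.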